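Compound 1 to compound 3: an ester swap in buffer

A few compounds are considered here, and "the series" means these few. Any claim that something is new, unique, unknown or untested is made for them only; others in the source may bear on it.

Measured compounds:
compound 1 `CCOC(=O)C1=C(S[C@@H]2CN[C@H](C(=O)Nc3cccc(C(=O)OCC)c3)C2)[C@H](C)[C@@H]2[C@@H]([C@@H](C)OC(=O)[C@@H](N)C(C)C)C(=O)N12` — in a physicochemical assay for metabolic stability, read by LC-MS, in phosphate buffer, with a stated time of 3 h, at pH 7.4, tested at 50 uM (on this read-out lower numbers stand for a less stable compound and higher numbers for a more stable compound), compound 1 gives > 95%, a limit of the assay.
compound 2 `C[C@@H](O)[C@H]1C(=O)N2C3=C(S[C@@H]4CN[C@@H](C4)C(=O)Nc4cccc(c4)C(=O)OCCCCOC3=O)[C@H](C)[C@H]12` — in this assay compound 2 gives > 95%, likewise a limit of the assay.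

Compound 1 therefore stands at the limit of > 95% in this assay, at which 2 of the 2 values shown sit; both readings shown are limits, so no order between them follows. Compound 3 `CCOC(=O)C1=C(S[C@@H]2CN[C@H](C(=O)Nc3cccc(C(=O)OCC)c3)C2)[C@H](C)[C@@H]2[C@@H]([C@@H](C)OC(=O)CC)C(=O)N12` differs from compound 1 in one place: ethyl in place of 1-amino-2-methylpropyl on a carbonyl carbon. Among the compounds with values here, no measured step between compounds differing in one place exists here, so the expected step is none beyond the scatter, namely a step that the limit leaves unreadable from compound 1 to compound 3. Compound 3 is expected at 96%, estimated between 85% and 100%.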

Compound 3, percent of the compound remaining: > 95%
Compound 3: no number, only a limit; the forecaster's own chance of this, stated with the estimate: 80%; the middle value lies beyond the limit too.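

No step from compound 1 to compound 3 can be read in this assay, because their readings are limits of the assay: the limit of > 95% in this assay, at which 3 of the 3 values shown sit.

The compounds shown leave open whether ethyl in place of 1-amino-2-methylpropyl changes the reading in this assay at all.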